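The source may hold more compounds than are shown below. What is called first, only, known or untested is meant among the compounds shown, and "the series" means these compounds.

Measured compounds:
- compound 1, `O=C(c1ccccc1)N1CCC(N(C2CC2)S(=O)(=O)c2cccc(C(F)(F)F)c2)CC1`, 42%
- compound 2, `CS(=O)(=O)c1ccc(C(=O)N2CCC(N(C3CC3)S(=O)(=O)c3cccc(C(F)(F)F)c3)CC2)cc1`, 52%
- compound 3, `NC(=O)c1cccc(C(=O)N2CCC(N(C3CC3)S(=O)(=O)c3cccc(C(F)(F)F)c3)CC2)c1`, 0%

In an assay on HEK293 cells for inhibition of Voltage-dependent N-type calcium channel subunit alpha-1B (Homo sapiens), read by FLIPR and calcium flux, tested at 1 uM (on this read-out higher numbers stand for more inhibition at the one concentration tested (going by the name of the read-out) and lower numbers for less inhibition), compound 3 gives 0%, the lowest of the three numbers. The nearest measured compound is compound 1 with 42%, and the step of a number 42 percentage points lower from compound 1 to compound 3 (beyond the scatter) lies beyond the scatter; compound 2 with 52% stands furthest, and a number 52 percentage points lower from compound 2 to compound 3 (beyond the scatter) is also beyond the scatter.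

Compound 4, `CS(=O)(=O)c1cccc(C(=O)N2CCC(N(C3CC3)S(=O)(=O)c3cccc(C(F)(F)F)c3)CC2)c1`, differs from compound 3 in one place: methylsulfonyl in place of carbamoyl on an aromatic carbon, on an aromatic carbon of a six-membered aromatic ring of carbon only, meta to a large group.

For the measured compounds named here, two measured steps bear on this. Attaching methylsulfonyl on the other phenyl position gave a number 10 percentage points higher from compound 1 to compound 2 (within the scatter), within the scatter, so that group on its own did not cost inhibition. Carbamoyl at the position now in question gave a number 42 percentage points lower from compound 1 to compound 3 (beyond the scatter), a large loss. Going by the values given here, removing that carbamoyl is expected to recover much of what was lost, but no compound shows methylsulfonyl at this exact position, so the size is uncertain.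

Compound 4 is therefore estimated at 30%, with a range from 0% to 60%. The step expected is a number 30 percentage points higher from compound 3 to compound 4 (beyond the scatter), an increase in this assay.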

Compound 4, a percentage reported as inhibition, at one concentration (the size of the read-out at that concentration, not a potency): 15%
Compound 4: the middle estimate sits 15 percentage points above what was measured, within the range that was stated.
By their numbers in this assay, from the lowest: compound 3; then compound 4; then compounds 1 and 2 (each within the scatter of the next).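

In this assay, exchanging carbamoyl for methylsulfonyl gave a number 15 percentage points higher from compound 3 to compound 4 (beyond the scatter), so the near-total loss seen with compound 3 depends in part on which group sits at this place, meta to a large group. The exchange does not restore the level of the unsubstituted phenyl, however: methylsulfonyl in place of hydrogen here gave a number 27 percentage points lower from compound 1 to compound 4 (beyond the scatter), so this place penalised both groups tested there, not carbamoyl alone. The same group also behaves differently according to where it stands on the ring: 3-(methylsulfonyl)phenyl in place of 4-(methylsulfonyl)phenyl gave a number 37 percentage points lower from compound 2 to compound 4 (beyond the scatter), whereas the 4-(methylsulfonyl)phenyl of compound 2 had shown only a number 10 percentage points higher from compound 1 to compound 2 (within the scatter) against the unsubstituted phenyl.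

The compounds shown leave open whether a smaller group at this place, such as a fluorine atom or a methoxy group, would stay level with compound 1, and whether an amine or a carboxylic acid would fall as far as carbamoyl did, or whether carbamoyl placed where compound 2 carries its methylsulfonyl would leave the number level with compound 2. Nothing available here accounts for the different sizes of these steps.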